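The source may report more compounds than this note shows. Statements on the series, on what has been measured and on what is new or still open speak of the compounds shown alone.

In a functional assay on HeLa cells (Homo sapiens) for antiproliferative activity, read by sulforhodamine B assay, with a stated time of 48 h (on this read-out higher numbers stand for weaker inhibition and lower numbers for stronger inhibition), two compounds have been measured so far:

Compound 1 `COc1cc(C(=O)/C=C\Nc2ccc(-c3nc4cc(OC)c(OC)c(OC)c4s3)cc2)c(Br)c(OC)c1OC` gives 6600 nM.
Compound 2 `COc1cc(OC)c2sc(-c3ccc(N/C=C\C(=O)c4ccc(OC)c(O)c4)cc3)nc2c1` gives 12100 nM.

Compound 1 stands at the lowest of these two numbers, but its gap to compound 2 lies within the usual scatter of repeated measurements, so the two cannot be separated on this assay; compound 2 also differs from compound 1 in more than one place, so nothing about any single change can be read from that pair.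

Compound 3 `COc1cc(OC)c2sc(-c3ccc(N/C=C\C(=O)c4cc(OC)c(OC)c(OC)c4Br)cc3)nc2c1` has not yet been measured. It differs from compound 1 in one place: hydrogen in place of methoxy on an aromatic carbon. The rest of the structure, including the enaminone linker and the brominated trimethoxyphenyl ketone, is unchanged.

Among the measured compounds shown here, no measured pair shows what this change alone does, so the expectation rests only on compound 1 and its number in this assay. The step from compound 1 to compound 3 is expected to be small, a 1.4-fold higher number from compound 1 to compound 3 (0.13 log units; within the scatter), and is not expected to reach beyond the scatter with confidence. Compound 3 is therefore estimated at 9000 nM, in a range from 3500 nM to 25000 nM.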

Compound 3, half-maximal inhibitory concentration: 10300 nM
The estimate for compound 3 lay 1.1-fold (0.06 log units) below the measured number; the range from low to high includes it.
By their numbers in this assay, from the lowest: compounds 1, 3 and 2 (each within the scatter of the next).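

In this assay, hydrogen in place of methoxy on this aromatic carbon of the shared core, ortho to two methoxy groups, gives a 1.6-fold higher number from compound 1 to compound 3 (0.19 log units; within the scatter). Among the compounds shown here, this is the first step that isolates a single place, and it shows that compound 1 and compound 3 cannot be separated on this read-out: with the enaminone linker and the brominated trimethoxyphenyl ketone unchanged, the presence or absence of this methoxy group makes no difference that can be told from the usual variation between repeated measurements. No independent measurement bears on this result, so nothing can be said about what lies behind it.

This single pair leaves open whether any other group on the same carbon, such as a fluorine atom, a hydroxyl, an amine or a longer chain like ethoxy, would move the number beyond the scatter in either direction. It also leaves open whether the same exchange would behave alike with a different ketone portion, since it has been read here on only one background.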